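Swapping Chloro for 1-Hydroxyethyl Without a Starting Number

The source may report more compounds than this note shows. Statements on the series, on what has been measured and on what is new or still open speak of the compounds shown alone.

Three related compounds frame this step, all tested in an ADME assay on Caco-2 cells (Homo sapiens) for permeability, in the apical to basolateral direction; on this read-out higher numbers stand for higher permeability and lower numbers for lower permeability. Compound 1 `CC(=O)N1CCN(c2cccc(-c3cc(-c4ccnn4C4CC4)c4c(N)ncnn34)c2)C(=O)C1(C)C` gives 36 nm/s, and compound 2 `COc1ccc(-c2cc(Cl)c3c(N)ncnn23)cc1N1CCN(C(C)=O)C(C)(C)C1=O` gives 170 nm/s. Compound 3 `CC(=O)N1CCN(c2cc(-c3cc(Cl)c4c(N)ncnn34)ccc2Cl)C(=O)C1(C)C` has no number at all: its result reads "not determined" (no result reported), so it cannot be ranked against the other two.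

Compound 4 `CC(=O)N1CCN(c2cc(-c3cc(Cl)c4c(N)ncnn34)ccc2C(C)O)C(=O)C1(C)C` is the same molecule as compound 3 apart from one group. The change is 1-hydroxyethyl in place of chloro on an aromatic carbon, ortho to a large group and para to a large group.

With no starting value, the size of this step in this assay can only be judged, not read off. Even so, I expect a moderate fall on going from compound 3 to compound 4, somewhat beyond the usual scatter of the measurement. Within the data shown here, this is a judgement, since no measured pair here shows the same swap. The closest measured relative of compound 4 is compound 2 at 170 nm/s, and I place my expectation below that value. The lower guide is compound 1 at 36 nm/s, and I expect a result not far above it. For compound 4 the estimated value is 80 nm/s, with an expected range from 30 nm/s to 200 nm/s.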

Compound 4, apparent permeability: 31 nm/s
Beside the measured number, compound 4's estimate is 2.6-fold (0.41 log units) above it; measured number inside the range.
By their numbers in this assay, from the lowest: compounds 4 and 1 (each within the scatter of the next); then compound 2.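

Compound 4 gives this position its first readable step in this assay, where exchanging methoxy for 1-hydroxyethyl goes with a 5.5-fold lower number from compound 2 to compound 4 (0.74 log units; beyond the scatter) and so moves the number by more than repeat measurements would. The earlier compounds shown here could not show that the group on this carbon, ortho to a large group and para to a large group, matters on this read-out, though this rests on a single pair of compounds. The swap of chloro for 1-hydroxyethyl itself still cannot be read, since compound 3 has no value to serve as a starting point.

No measurement offered here explains why the number falls with this swap. From the compounds shown here alone, it also remains open whether an ethyl group, which lacks the oxygen of 1-hydroxyethyl, or an aminomethyl group or a carboxylic acid on this same carbon would give a number closer to that of compound 2 or to that of compound 4.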